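A Chloro Substituent Carried Across Two Related Cores

The source may report more compounds than this note shows. Statements on the series, on what has been measured and on what is new or still open speak of the compounds shown alone.

In a functional assay on NCI/ADR-RES cells (Homo sapiens) for inhibition, read by sulforhodamine B assay, with a stated time of 48 h (on this read-out higher numbers stand for weaker inhibition of growth and lower numbers for stronger inhibition of growth), the measured compounds stand as follows:
compound 1 `N#Cc1c(-c2nnc(-c3nn(-c4ccccc4)c(-c4ccccc4)c3C#N)c3nn(-c4ccccc4)cc23)nn(-c2ccccc2)c1-c1ccccc1`, 24500 nM
compound 2 `N#Cc1c(-c2nnc(-c3nn(-c4ccccc4)c(-c4ccccc4)c3C#N)c3nn(-c4ccc(Cl)cc4)cc23)nn(-c2ccccc2)c1-c1ccccc1`, 7460 nM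
compound 3 `N#Cc1c(-c2nnc(-c3ccccc3)c3nn(-c4ccccc4)cc23)nn(-c2ccccc2)c1-c1ccccc1`, > 100000 nM

The value of compound 3 is a limit of this assay and not a number (the limit of > 100000 nM in this assay, at which 1 of the 3 values shown sits). Compound 2 differs from compound 1 by chloro in place of hydrogen on an aromatic carbon, and this change gave a 3.3-fold lower number from compound 1 to compound 2 (0.52 log units; beyond the scatter). The difference between the core of compound 1 and the core of compound 3 is not broken down here.

Compound 4 `N#Cc1c(-c2nnc(-c3ccccc3)c3nn(-c4ccc(Cl)cc4)cc23)nn(-c2ccccc2)c1-c1ccccc1` has not yet been measured in this assay; it differs from compound 3 by chloro in place of hydrogen on an aromatic carbon, the same change at the same kind of place. Because compound 3 offers only a limit (the limit of > 100000 nM in this assay, at which 1 of the 3 values shown sits), the starting point for compound 4 is itself uncertain. The change from compound 3 to compound 4 is expected to give an at least 1.6-fold lower number from compound 3 to compound 4 (0.22 log units; that floor lies within the scatter), a size that rests on a 3.3-fold lower number from compound 1 to compound 2 (0.52 log units; beyond the scatter), while compound 4 may also end as a limit. On that basis compound 4 is estimated at 60000 nM, within 20000 nM to 200000 nM.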

Compound 4, concentration for 50% growth inhibition: 2280 nM
Compound 4: the middle estimate sits 26-fold (1.42 log units) above what was measured, and the stated range ends above it.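

In this assay, the change from phenyl to 4-chlorophenyl gave an at least 43-fold lower number from compound 3 to compound 4 (1.64 log units; beyond the scatter), so the direction seen on the core of compound 1 also held on the core of compound 3. The direction carried from one core to the other, but the size did not: the same change on two cores in this assay, a 3.3-fold lower number (0.52 log units; beyond the scatter) from compound 1 to compound 2 and an at least 43-fold lower number (1.64 log units; beyond the scatter) from compound 3 to compound 4, at least 13-fold (1.12 log units) apart, beyond the scatter of two such steps

Compound 3 stands at a limit of the assay and not a number, so the step on its core is only a floor, and the two cores show neither its true size nor why the two steps differ: the limit of > 100000 nM in this assay, at which 1 of the 4 values shown sits.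

The compounds shown leave open whether another group on the same aromatic carbon, such as fluoro, bromo, methoxy or an amine, would also lower the number in this assay. They also leave open how large the step from phenyl to 4-chlorophenyl would be on any third core.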